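Moving the hydroxyl group from compound 3 to compound 4

The source may hold more compounds than are shown below. What is called first, only, known or untested is meant among the compounds shown, and "the series" means these compounds.

Of the compounds shown here, three have so far been measured in an ADME assay on MT2 cells (Homo sapiens) for cytotoxicity, read by XTT assay, with a stated time of 4 days; a higher number here means that more compound is tolerated, a lower number that less compound is tolerated. Compound 1 `Cc1cc(C=C(C#N)C#N)c(C)n1-c1cccc(-c2nnn[nH]2)c1` gives > 400000 nM, which is a limit of the assay rather than a number. Compound 2 `CCOC(=O)/C(C#N)=C/c1cc(C)n(-c2cccc(-c3nnn[nH]3)c2)c1C` gives 76800 nM in this assay, and compound 3 `Cc1cc(/C=C2\SC(=S)N(c3cccc(O)c3)C2=O)c(C)n1-c1cccc(-c2nnn[nH]2)c1` gives 35600 nM, the lower of the two numbers; the gap between compound 2 and compound 3 lies beyond the scatter. Within the data shown here, the single measured step, an at least 5.2-fold lower number from compound 1 to compound 2 (0.71 log units; beyond the scatter), exchanges the group on an aromatic carbon and leaves untouched the part of the molecule that changes here.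

Compound 4 `Cc1cc(/C=C2\SC(=S)N(c3ccc(O)cc3)C2=O)c(C)n1-c1cccc(-c2nnn[nH]2)c1` differs from compound 3 only by 4-hydroxyphenyl in place of 3-hydroxyphenyl on an amide-type nitrogen in a ring. Among the measured compounds shown here, no measured step concerns a change of this kind, so there is no basis for expecting a shift beyond the scatter in either direction. The step expected is therefore a 1.0-fold lower number from compound 3 to compound 4 (0.01 log units; within the scatter), essentially none. On this footing compound 4 is estimated at 35000 nM, with a range from 15000 nM to 80000 nM.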

Compound 4, half-maximal cytotoxic concentration: 45600 nM
For compound 4 the middle estimate is 1.3-fold (0.11 log units) below the measured one; measured number inside the range.
By their numbers in this assay, from the lowest: compounds 3, 4 and 2 (each within the scatter of the next, the first and the last beyond it). At a limit, above all of these: compound 1.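

In this assay, among these compounds, the first step at this place on the amide-type nitrogen in a ring is a 1.3-fold higher number from compound 3 to compound 4 (0.11 log units; within the scatter). Among the compounds shown here, the only earlier step, an at least 5.2-fold lower number from compound 1 to compound 2 (0.71 log units; beyond the scatter), changed a different part of the molecule and lay beyond the scatter, so it said nothing about this group. The new step shows that exchanging 3-hydroxyphenyl for 4-hydroxyphenyl, two groups with the same counted atoms, does not separate the two compounds in this assay.

What the compounds shown leave open is whether a different group on this six-membered aromatic ring, such as an amine, a carboxylic acid or a longer chain ending in a methoxy group, would shift the number in this assay beyond the scatter. Nothing known from these data bears on why 3-hydroxyphenyl and 4-hydroxyphenyl give values within the scatter of each other.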